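The compounds below may be only part of what the source reports. "The series", "measured", "known", "first", "only" and "open" are said of these compounds alone.

Working notes on the coumarin series in an assay (strain Wistar) for inhibition of Amine oxidase [flavin-containing] A (Rattus norvegicus); on this read-out lower numbers stand for stronger inhibition and higher numbers for weaker inhibition.

Compound 1 `NC(=O)[C@H](CO)Nc1cc(=O)oc2cc(OCc3cccc(Cl)c3)ccc12` carries a (1-carbamoyl-2-hydroxyethyl)amino group on the core; in this assay compound 1 reaches only the limit of the assay, > 100000 nM, and no number (the limit of > 100000 nM in this assay, at which 1 of the 3 values shown sits). Compound 2 `NC(=O)Cc1cc(=O)oc2cc(OCc3ccccc3)ccc12` gives 8000 nM. Compound 3 `NC(=O)Cc1cc(=O)oc2cc(OCc3cccc(Cl)c3)ccc12` gives 26000 nM, the higher of the two numbers in this assay, with compound 2 as its nearest neighbour. Two measured steps frame it: an at least 3.8-fold lower number from compound 1 to compound 3 (0.58 log units; beyond the scatter) and a 3.3-fold higher number from compound 2 to compound 3 (0.51 log units; beyond the scatter).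

Compound 4 `CN(Cc1ccccc1)Cc1cc(=O)oc2cc(OCc3cccc(Cl)c3)ccc12` differs from compound 3 by benzyl(methyl)amino in place of carbamoyl on a saturated chain carbon bound to an aromatic carbon. Neither measured step bears directly on this change: the step from compound 1 to compound 3 removes a polar amino-acid amide from the core, and the step from compound 2 to compound 3 concerns only the chloro on the benzyl ring. The change in compound 4 is therefore poorly anchored. Compound 4 is expected to give 10000 nM, within 1500 nM to 60000 nM, which means an expected step of a 2.6-fold lower number from compound 3 to compound 4 (0.41 log units; beyond the scatter).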

Compound 4, half-maximal inhibitory concentration: > 100000 nM
Compound 4: a limit, no number; the forecaster's own chance of this, stated with the estimate: 15%; middle value at least 10-fold (1.00 log units) away from the limit.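

At the saturated chain carbon bound to an aromatic carbon, benzyl(methyl)amino in place of carbamoyl gives an at least 3.8-fold higher number from compound 3 to compound 4 (0.58 log units; beyond the scatter) in this assay, so at this position the carbamoyl of compound 3 cannot be swapped for this amine, with its six-membered aromatic ring, without a loss of inhibition. Compound 4 stands at a limit of the assay and not at a number, so the step gives only a lower bound on the loss, and compound 1 stands at the same limit: the limit of > 100000 nM in this assay, at which 2 of the 4 values shown sit. The step from compound 1 to compound 4 cannot be read, with a limit at each end.

As far as these compounds go, it remains open whether the loss follows the amine nitrogen or the benzyl group. From the compounds shown here alone, a dimethylamino group or a carboxylic acid at this carbon would separate these readings, and the effect of the chloro on the benzyl ring alongside benzyl(methyl)amino also remains open.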